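The source may hold more compounds than are shown below. What is called first, only, known or untested is meant among the compounds shown, and "the series" means these compounds.

Three compounds of this series have a measured value. In an ADME assay on MT4 cells (Homo sapiens) for cytotoxicity, read by spectrophotometry, with a stated time of 5 days (a lower number here means that less compound is tolerated, a higher number that more compound is tolerated), compound 1 (`CONC(=S)N/N=C1\C(=O)N(CN2CCN(c3ccc(OC)cc3)CC2)c2ccc(C)cc21`) gives 324000 nM and compound 2 (`COc1ccc(N2CCN(CN3C(=O)/C(=N\NC(=S)NO)c4cc(Cl)ccc43)CC2)cc1`) gives 279000 nM while compound 3 (`CONC(=S)N/N=C1\C(=O)N(CN2CCN(c3ccccc3)CC2)c2ccc(Cl)cc21`) gives 267000 nM in the same test. The value of compound 3 lies within the scatter of both others, so it holds no distinct place among them.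

The next compound to be tested is compound 4 (`CONC(=S)N/N=C1\C(=O)N(CN2CCN(c3ccc(OC)cc3)CC2)c2ccc(Cl)cc21`). It departs from compound 3 at one place, with methoxy in place of hydrogen on an aromatic carbon, para to a large group (methoxy in place of hydrogen on an aromatic carbon). The same difference, cut one bond further out, reads phenyl to 4-methoxyphenyl.

Among the measured compounds shown here, no pair of measured compounds differs in one place only, so the size of this change has not been seen directly. Compound 2 also carries the 4-methoxyphenyl group and gives 279000 nM in this series, and compound 1 carries it too and gives 324000 nM here. Neither value stands apart from that of compound 3, so in this assay no step beyond the scatter is expected. The estimated outcome is a 1.1-fold higher number from compound 3 to compound 4 (0.04 log units; within the scatter) and it carries no firm direction. For compound 4 the expected value is 290000 nM with an estimated range from 170000 nM to 480000 nM as its likely span.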

Compound 4, half-maximal cytotoxic concentration: 221000 nM
The estimate for compound 4 lay 1.3-fold (0.12 log units) above the measured number; measured number inside the range.
By their numbers in this assay, from the lowest: compounds 4, 3, 2 and 1 (each within the scatter of the next).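

Among the compounds shown here, for the first time, single changes can be read directly in this assay. Methoxy in place of hydrogen on an aromatic carbon, para to a large group, gives a 1.2-fold lower number from compound 3 to compound 4 (0.08 log units; within the scatter) for the change from phenyl to 4-methoxyphenyl, so this change leaves the number within the scatter at this place. The two other single changes read the same way, with methyl in place of hydrogen on an oxygen giving a 1.3-fold lower number from compound 2 to compound 4 (0.10 log units; within the scatter) and chloro in place of methyl on an aromatic carbon giving a 1.5-fold lower number from compound 1 to compound 4 (0.17 log units; within the scatter) in the same test, while no measurement at hand offers an explanation for any of these steps.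

The compounds shown leave open whether a different group at this place on the aromatic ring, such as an amine, a carboxylic acid or a longer chain on the oxygen, would give a step beyond the scatter. They also leave open whether changing the shared core itself, rather than these three small substituents, would move the number in this assay to any clear degree.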